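The compounds below may be only part of what the source reports. "The series", "measured", "known", "first", "only" and "open" are said of these compounds alone.

Going by the values given here, compound 2 `COc1cc(NC(C)CCCNC(=O)NNC(=O)Nc2cccc(Cl)c2)c2ncccc2c1` is the only compound with a numerical reading in a functional assay on HeLa cells (Homo sapiens) for inhibition, read by MTT assay, with a stated time of 72 h; on this read-out higher numbers stand for weaker inhibition and lower numbers for stronger inhibition: compound 2 gives 44000 nM. Compound 1 `COc1cc(NC(C)CCCNC(=O)NNC(=O)Nc2cccc(F)c2)c2ncccc2c1` reaches only a limit of the assay, as compound 1 gives > 250000 nM in this assay. Among the compounds with values here, the one measured step, an at least 5.6-fold lower number from compound 1 to compound 2 (0.75 log units; beyond the scatter), concerns a halogen swap on the aromatic ring. Compound 3 `COc1cc(NC(C)CCCNC(=O)Nc2cccc(Cl)c2)c2ncccc2c1` differs from compound 2 in another way: 3-chlorophenyl in place of ((3-chlorophenyl)carbamoyl)amino on an amide-type nitrogen. Within the data shown here, no measured step bears on this kind of change, so the account can draw no direction from the halogen step for it, and expects no step beyond the scatter from compound 2 to compound 3 in this assay, though with wide uncertainty. Compound 3 is therefore expected to give roughly 45000 nM in this assay, within a range of 8000 nM to 250000 nM, which would mean an estimated step of a 1.0-fold higher number from compound 2 to compound 3 (0.01 log units; within the scatter).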

Compound 3, half-maximal inhibitory concentration: 17000 nM
Estimate against measurement, compound 3: 2.6-fold (0.42 log units) above, and the stated range covers the measured number.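

In this assay, the second urea unit proves dispensable at this amide-type nitrogen: 3-chlorophenyl in place of ((3-chlorophenyl)carbamoyl)amino gives a 2.6-fold lower number from compound 2 to compound 3 (0.41 log units; beyond the scatter). The wider comparison, which also carries the halogen swap, gives an at least 14-fold lower number from compound 1 to compound 3 (1.16 log units; beyond the scatter). Compound 1 stands at a limit of the assay, so this wider step is a bound and not a size: the limit of > 250000 nM in this assay, at which 1 of the 3 values shown sits.

The compounds shown leave open whether a fluoro in place of the chloro would cost as much on the 3-chlorophenyl group as it does in the longer unit, or whether a bromo or methyl would read differently there. They also leave open how this assay would respond to an amine or a carboxylic acid on that aromatic ring, or to a longer chain in place of the 3-chlorophenyl.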